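Aryl urea series: from compound 2 toward compound 3

The source may hold more compounds than are shown below. What is called first, only, known or untested is meant among the compounds shown, and "the series" means these compounds.

Going by the values given here, compound 2 `COc1cccc(NC(=O)N[C@H]2CC[C@H](Oc3ccc(F)cc3)CC2)c1` carries the highest number of the two measured so far: in a functional assay on CRL2813 cells (Homo sapiens) for cytotoxicity, read by sulforhodamine B assay, with a stated time of 5 days (a lower number here means a stronger inhibitor, a higher number a weaker inhibitor), compound 2 gives 14000 nM, whereas compound 1 `O=C(Nc1cccc(C(F)(F)F)c1)N[C@H]1CC[C@@H](Oc2ccc(F)cc2)CC1` gives 2600 nM, a gap beyond the usual scatter. Compound 3 `Cc1ccccc1NC(=O)N[C@H]1CC[C@H](Oc2ccc(F)cc2)CC1` is the next member to be tested and differs from compound 2 in one place: 2-methylphenyl in place of 3-methoxyphenyl on an amide-type nitrogen. Among the compounds with values here, no measured pair covers this change, so its direction is uncertain; a modest move toward a lower number is expected, roughly at the edge of the scatter. Compound 3 is therefore estimated at 9000 nM, within 3000 nM to 27000 nM, which means a step of a 1.6-fold lower number from compound 2 to compound 3 (0.19 log units; within the scatter).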

Compound 3, half-maximal inhibitory concentration: > 20000 nM
Compound 3 ended at the assay's limit; the forecaster's own chance of this, stated with the estimate: 5%; at least 2.2-fold (0.34 log units) between middle value and limit.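

The change from 3-methoxyphenyl to 2-methylphenyl on an amide-type nitrogen gives the series its first single-place step in this assay, with an at least 1.4-fold higher number from compound 2 to compound 3 (0.15 log units; that floor lies within the scatter). This step shows no move toward a lower number at this position, although its floor stays within the scatter and its full size cannot be read. Compound 3 stands at a limit of the assay: the limit of > 20000 nM in this assay, at which 1 of the 3 values shown sits.

The compounds shown do not separate the effect of the group from that of its place on the aromatic ring. They also leave open what an amine or a carboxylic acid on that ring would give.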